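Swapping one phenyl for pyridin-2-yl in an acylguanidine agonist

This account rests on a few compounds, and the source may have more. Where it says the series, first, only, none or still open, it means among the compounds named here.

This account concerns a pair of acylguanidines measured in a functional assay on cardiac atrium for agonist activity at histamine H2 receptor (Cavia porcellus) (on this read-out higher numbers stand for an effect only at larger amounts of compound and lower numbers for an effect already at smaller amounts), and another compound that has yet to be tested. Compound 1 `N=C(NCCCc1c[nH]cn1)NC(=O)CC(c1ccccc1)c1ccccc1` gives 28.2 nM in this assay, the lowest of the two numbers recorded. Compound 2 `N=C(NCCCc1c[nH]cn1)NC(=O)C(c1ccccc1)c1ccccc1`, which carries its two phenyl groups on a carbon one position closer to the carbonyl, gives 1050 nM in this assay, a markedly higher number that lies well beyond the usual scatter. Within the data shown here, no single-point step between measured compounds is available to calibrate the next change.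

Compound 3 `N=C(NCCCc1c[nH]cn1)NC(=O)CC(c1ccccc1)c1ccccn1` differs from compound 1 by pyridin-2-yl in place of phenyl on a saturated chain carbon bound to an aromatic carbon and a saturated chain carbon. Among the measured compounds shown here, since the chain length that distinguishes compound 1 from compound 2 is kept, and only one aromatic ring is exchanged for an aromatic ring of the same size bearing one nitrogen, a modest step is expected rather than a large one. The estimated step from compound 1 to compound 3 in this assay is a 2.4-fold lower number from compound 1 to compound 3 (0.37 log units; beyond the scatter), leaning toward a somewhat lower number. Compound 3 is therefore expected to give about 12 nM in this assay, within a range from 3 nM to 45 nM.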

Compound 3, half-maximal effective concentration: 51.3 nM
Compound 3: the middle estimate sits 4.3-fold (0.63 log units) below what was measured; measured number outside the range, above it.
By their numbers in this assay, from the lowest: compounds 1 and 3 (each within the scatter of the next); then compound 2.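

In this assay, the exchange of phenyl for pyridin-2-yl on a saturated chain carbon bound to an aromatic carbon and a saturated chain carbon gives a 1.8-fold higher number from compound 1 to compound 3 (0.26 log units; within the scatter), so compound 3 cannot be told apart from compound 1 on this read-out. Among these compounds, this is the first single-change step available for the series, and it shows that one of the two rings at this carbon can carry a ring nitrogen, and with it one hydrogen-bond acceptor where phenyl has none, without a change that stands clear of the usual scatter. No accompanying measurement bears on why the exchange leaves the number within the scatter.

As far as these compounds go, it remains open whether the same holds for pyridin-3-yl or pyridin-4-yl at this carbon, or for a ring carrying an added group such as fluoro or methoxy. Also open, from the compounds shown here alone, is whether replacing the second phenyl with pyridin-2-yl would stay within the scatter as well, and whether the same exchange would behave alike on the core of compound 2.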